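Methylsulfonyl for methoxy on a pyridyl core

A few compounds are considered here, and "the series" means these few. Any claim that something is new, unique, unknown or untested is made for them only; others in the source may bear on it.

In an ADME assay on cells (Hepatocyte, Homo sapiens) for metabolic stability, with a stated time of 90 min (on this read-out higher numbers stand for fast clearance and lower numbers for slow clearance), compound 1 `CCC(CC)CNc1c(C(N)=O)cnc2ccc(-c3ccc(COC)cc3)cc12` gives 21 uL/min. Compound 2 `CCC(CC)CNc1c(C(N)=O)cnc2ccc(-c3ccc(CS(C)(=O)=O)cc3)cc12` gives 23 uL/min; the change methylsulfonyl in place of methoxy on a saturated chain carbon bound to an aromatic carbon gave a 1.1-fold higher number from compound 1 to compound 2 (0.04 log units; within the scatter). Compound 3 `CCC(CC)CNc1c(C(N)=O)cnc2ccc(-c3ccc(COC)nc3)cc12` returns only a limit in this assay, < 6.8 uL/min, which is the limit of < 6.8 uL/min in this assay, at which 1 of the 3 values shown sits. Its core differs from that of compound 1 by 6-(methoxymethyl)pyridin-3-yl in place of 4-(methoxymethyl)phenyl on an aromatic carbon, a change that gave an at least 3.0-fold lower number from compound 1 to compound 3 (0.48 log units; beyond the scatter).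

Compound 4 `CCC(CC)CNc1c(C(N)=O)cnc2ccc(-c3ccc(CS(C)(=O)=O)nc3)cc12` carries the change (methylsulfonyl in place of methoxy on a saturated chain carbon bound to an aromatic carbon), the same change as that from compound 1 to compound 2, made on a place described in the same words. For compound 4 the expected step is a step that the limit leaves unreadable from compound 3 to compound 4, resting on a 1.1-fold higher number from compound 1 to compound 2 (0.04 log units; within the scatter) measured on the other core. Compound 4 is therefore estimated at 6 uL/min, with a range of 3 uL/min to 12 uL/min in this assay, and a limit is again likely to be reported.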

Compound 4, intrinsic clearance in a liver preparation (reported as CLH), per the amount of preparation that the assay uses in the Hepatocyte assay: 15 uL/min
Beside the measured number, compound 4's estimate is 2.5-fold (0.40 log units) below it; the measured number lies above the stated range.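

In the Hepatocyte assay, methylsulfonyl in place of methoxy gave an at least 2.2-fold higher number from compound 3 to compound 4 (0.34 log units; beyond the scatter), a step that starts from a limit and so does not show that the change carries over differently between the two cores: the same change on two cores in the Hepatocyte assay, a 1.1-fold higher number (0.04 log units; within the scatter) from compound 1 to compound 2 and an at least 2.2-fold higher number (0.34 log units; beyond the scatter) from compound 3 to compound 4; the limit leaves it open whether they differ

In a physicochemical assay for lipophilicity, using the shake flask method, measured as octanol-water partition, at pH 7.4 (on this read-out lower numbers stand for lower lipophilicity and higher numbers for higher lipophilicity), compound 3 gives > 4.3, which is a limit. In the physicochemical assay, compound 4 gives 3.1, so on this core the same change also gave a number at least 1.20 log units lower from compound 3 to compound 4 (beyond the scatter).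

The compounds shown leave open how a hydroxyl or a dimethylamino group, on a saturated chain carbon bound to an aromatic carbon, would read in the Hepatocyte assay and the physicochemical assay on either core.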